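This account rests on a few compounds, and the source may have more. Where it says the series, first, only, none or still open, it means among the compounds named here.

Compound 1 `COc1ccc(C2=C(c3cc(OC)c(OC)c(OC)c3)C(=O)C(O)C2)cc1` carries a free hydroxyl on a saturated ring carbon. In an ADME assay on HT-29 cells (Homo sapiens) for cytotoxicity, read by MTT assay, with a stated time of 72 h (a higher number here means a weaker inhibitor, a lower number a stronger inhibitor), compound 1 reaches the limit < 1 ug/mL, which is a limit of the method rather than a number (the limit of < 1 ug/mL in this assay, at which 1 of the 3 values shown sits). Compound 3 `COc1ccc(C2=C(c3cc(OC)c(OC)c(OC)c3)C(=O)C(O[SiH2]C(C)(C)C)C2)cc1` differs from compound 1 by a hydrogen atom in place of a group of 5 heavy atoms (4 carbon, 1 silicon; no ring), on an oxygen on a saturated carbon. In this assay compound 3 gives 5 ug/mL. The step of an at least 5.0-fold lower number from compound 3 to compound 1 (0.69 log units; beyond the scatter) shows that loss of the silicon-containing group leaves a stronger inhibitor.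

Compound 2 `COc1ccc(OC)c(C2=C(c3cc(OC)c(OC)c(OC)c3)C(=O)CC2O[SiH2]C(C)(C)C)c1` carries the same silicon-containing group on another core; the difference between the two cores is not broken down here. In this assay compound 2 gives 5 ug/mL, the same number as compound 3.

Compound 4 `COc1ccc(OC)c(C2=C(c3cc(OC)c(OC)c(OC)c3)C(=O)CC2O)c1` has not yet been measured. It differs from compound 2 by a hydrogen atom in place of a group of 5 heavy atoms (4 carbon, 1 silicon; no ring), on an oxygen on a saturated carbon, the same change as that from compound 3 to compound 1. Compound 2 stands where compound 3 stands, and the step of an at least 5.0-fold lower number from compound 3 to compound 1 (0.69 log units; beyond the scatter) was at least modest. On that footing the step expected for compound 4 is a 5.0-fold lower number from compound 2 to compound 4 (0.70 log units; beyond the scatter). Compound 4 is therefore estimated at 1 ug/mL, between 0.3 ug/mL and 3 ug/mL, and may well return only a limit.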

Compound 4, half-maximal inhibitory concentration: > 100 ug/mL
Compound 4: no number, only a limit; the forecaster's own chance of this, stated with the estimate: 50%; middle value at least 100-fold (2.00 log units) away from the limit.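

In this assay compound 4 gives > 100 ug/mL, which is a limit of the assay and not a number. Putting a hydrogen atom in place of the silicon-containing group on this core gives an at least 20-fold higher number from compound 2 to compound 4 (1.30 log units; beyond the scatter), opposite in direction to the step on the core of compound 1, so in these two pairs the change does not carry from one core to the other: the same change on two cores in this assay, an at least 5.0-fold lower number (0.69 log units; beyond the scatter) from compound 3 to compound 1 and an at least 20-fold higher number (1.30 log units; beyond the scatter) from compound 2 to compound 4, at least 100-fold (2.00 log units) apart, beyond the scatter of two such steps These two pairs do not show which difference between the cores lies behind this reversal, nor how the change would behave on any third core, and the gap between the steps is known only as a bound, since compound 1 and compound 4 both rest on limits.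

The compounds shown leave open how each core responds to other groups on that oxygen, such as a methyl ether or an acetyl ester. Also open, as far as these compounds go, is where compound 1 and compound 4 would stand as numbers rather than limits.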